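This account rests on a few compounds, and the source may have more. Where it says the series, first, only, none or still open, it means among the compounds named here.

Measured compounds:
compound 1 `Cc1ccc(NC(=O)N[C@H](C)c2ccccc2)cc1` gives 64% in an ADME assay on the whole organism with Oryza sativa as the target, tested at 10 uM; a higher number here means a weaker effect of the compound at the concentration tested, a lower number a stronger effect;
compound 2 `Cc1ccc(NC(=O)N[C@@H](C)c2ccccc2)cc1` gives 100% in this assay;
compound 3 `CC(C)c1cccc(NC(=O)N[C@H](C)c2ccccc2)c1` gives 44% in this assay.

Compound 1 stands second highest of these three numbers. For the measured compounds named here, its nearest neighbour is compound 3, whose value lies lower, a gap beyond the scatter; its furthest is compound 2, the change a number 36 percentage points higher from compound 1 to compound 2 (beyond the scatter) being the only step between measured compounds here. That step rests on (the fact that compounds 1 and 2 differ only in the configuration as drawn), and it says nothing about alkyl groups on the aromatic ring.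

Compound 4 `CCCCCCc1ccc(NC(=O)N[C@H](C)c2ccccc2)cc1` is not yet measured. It differs from compound 1 by pentyl in place of hydrogen on a saturated chain carbon bound to an aromatic carbon. Going by the values given here, no measured step covers a change of this kind. Among the compounds with values here, compound 3 carries a larger alkyl group than compound 1 and gives the lower number of the two, but no single-point step joins them, so this is only what their two values show.

Within the data shown here, with no step bearing on the change, the account expects at most a modest movement for compound 4 in this assay, leaning toward a lower number: the estimate is 55%, with a range from 25% to 90%. The expected step of a number 9 percentage points lower from compound 1 to compound 4 (within the scatter) is therefore small and uncertain.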

Compound 4, a percentage reported as activity, at one concentration (the size of the read-out at that concentration, not a potency): 101%
Compound 4: middle estimate off by 46 percentage points, on the low side; the measured number lies above the stated range.
By their numbers in this assay, from the lowest: compound 3; then compound 1; then compounds 2 and 4 (each within the scatter of the next).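

At this position, on a saturated chain carbon bound to an aromatic carbon, pentyl in place of hydrogen (the same difference reads as methyl to hexyl) gives a number 37 percentage points higher from compound 1 to compound 4 (beyond the scatter) in this assay, so a higher number here means a weaker effect at the concentration tested. Compound 4 keeps the configuration drawn in compound 1, so this step comes from a change in the chain alone and shows that the number responds to the group at this position as well as to the configuration, although this rests on a single pair of compounds. The evidence at hand concerns only configuration, and nothing in it bears on why this chain change moves the number.

The compounds shown leave open whether the number climbs gradually or only beyond a certain length, which an ethyl, propyl or butyl group at the same place could settle, and whether an amine or a carboxylic acid at the end of the hexyl chain would change the result. They also leave open whether the hexyl compound drawn with the opposite configuration would behave as compound 2 does.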